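Chain extension on the amide of a pyrimidine-fused series

The compounds below may be only part of what the source reports. "The series", "measured", "known", "first", "only" and "open" are said of these compounds alone.

Compound 1 `CCC1C(=O)N(C)c2cnc(Nc3ccc(S(=O)(=O)NCC(C)C)cc3)nc2N1c1ccn(C)n1` gives 31600 nM in a functional assay on A549 cells (Homo sapiens) for antiproliferative activity, read by CCK-8 assay, with a stated time of 72 h (on this read-out lower numbers stand for stronger inhibition of growth and higher numbers for weaker inhibition of growth), and compound 2 `CCCNS(=O)(=O)c1ccc(Nc2ncc3c(n2)N(c2ccn(C)n2)C(CC)C(=O)N3C)cc1` gives 15000 nM. Between them the change is methyl in place of hydrogen on a saturated chain carbon bound to two saturated chain carbons, and the step is a 2.1-fold higher number from compound 2 to compound 1 (0.32 log units; beyond the scatter). Compound 3 `CCCNC(=O)c1ccc2c(ccn2-c2ncc3c(n2)N(C2CCCC2)[C@H](CC)C(=O)N3C)c1` gives 1640 nM; the difference between the core of compound 3 and the core of compound 2 is not broken down here. Compound 4 `CCCCNC(=O)c1ccc2c(ccn2-c2ncc3c(n2)N(C2CCCC2)[C@H](CC)C(=O)N3C)c1` is not yet measured; it carries methyl in place of hydrogen on a saturated chain carbon, three bonds along the chain from an amide-type nitrogen, the same kind of change as that from compound 2 to compound 1 but not the same, since the place differs: here the carbon sits three bonds along the chain from an amide-type nitrogen, there it was bound to two saturated chain carbons. Because the measured step is a 2.1-fold higher number from compound 2 to compound 1 (0.32 log units; beyond the scatter) and the new chain is linear rather than branched, the step for compound 4 is expected to be small, near a 1.3-fold higher number from compound 3 to compound 4 (0.11 log units; within the scatter). Compound 4 is therefore estimated at 2100 nM, between 900 nM and 4800 nM.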

Compound 4, concentration for 50% growth inhibition: 1160 nM
The estimate for compound 4 lay 1.8-fold (0.26 log units) above the measured number; low and high end bracket the measured number.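

In this assay the added methyl gives a 1.4-fold lower number from compound 3 to compound 4 (0.15 log units; within the scatter) and so leaves the two amides unresolved. The same kind of change does not carry over in size from one core to the other: the same change on two cores in this assay, a 2.1-fold higher number (0.32 log units; beyond the scatter) from compound 2 to compound 1 and a 1.4-fold lower number (0.15 log units; within the scatter) from compound 3 to compound 4, 3.0-fold (0.47 log units) apart, beyond the scatter of two such steps. This does not show what separates the two steps, since the core and the place of the methyl both differ, a saturated chain carbon bound to two saturated chain carbons in one case and a saturated chain carbon three bonds along the chain from an amide-type nitrogen in the other, and each core supplies a single step.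

Still open, on these data alone, is whether a chain longer than butyl on this amide moves the number beyond the scatter. Also open, as far as these compounds go, is what an amine or a carboxylic acid at the end of the chain would do.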